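This account rests on a few compounds, and the source may have more. Where it says the series, first, only, none or still open, it means among the compounds named here.

Measured compounds:
compound 1, `COc1ccc(/C=C2/S/C(=N/c3ccccc3)N(Cc3ccncc3)C2=O)cc1`, 19100 nM
compound 2, `CCOc1cc(/C=C2/S/C(=N/c3ccccc3)N(Cc3ccncc3)C2=O)ccc1O`, 20400 nM
compound 3, `O=C1/C(=C\c2ccccn2)S/C(=N/c2ccccc2)N1Cc1ccncc1`, 31000 nM

All three share the same core and differ only in the group on the double-bonded chain carbon bound to a double-bonded ring carbon. In a functional assay on HepG2 cells (Homo sapiens) for cytotoxicity, read by MTT assay, with a stated time of 48 h (on this read-out lower numbers stand for stronger inhibition and higher numbers for weaker inhibition), compound 1 gives the lowest of the three numbers, but neither neighbour is separated from it by more than the scatter: a 1.1-fold higher number from compound 1 to compound 2 (0.03 log units; within the scatter) and a 1.6-fold higher number from compound 1 to compound 3 (0.21 log units; within the scatter). The remaining pair behaves the same way, a 1.5-fold higher number from compound 2 to compound 3 (0.18 log units; within the scatter). Within this small set, exchanging the group at that position has not moved the read-out beyond the scatter.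

Compound 4, `Cc1ccc(/C=C2/S/C(=N/c3ccccc3)N(Cc3ccncc3)C2=O)s1`, is the next variation at the same position. Compared with compound 1: 5-methylthiophen-2-yl in place of 4-methoxyphenyl on a double-bonded chain carbon bound to a double-bonded ring carbon

For the measured compounds named here, the steps that bear on this change are the two already seen at that position, from compound 1 to compound 2 and from compound 1 to compound 3, both within the scatter. Going by the values given here, no step seen so far gives grounds for a shift beyond the scatter in this assay, so compound 4 is expected to land near compound 1, with a 1.2-fold higher number from compound 1 to compound 4 (0.06 log units; within the scatter) as the estimated step. The estimate for compound 4 is 22000 nM, with a range from 9000 nM to 55000 nM.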

Compound 4, half-maximal inhibitory concentration: 23100 nM
Beside the measured number, compound 4's estimate is 1.1-fold (0.02 log units) below it; the range from low to high includes it.
By their numbers in this assay, from the lowest: compounds 1, 2, 4 and 3 (each within the scatter of the next).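

In this assay, the earlier groups at the double-bonded chain carbon bound to a double-bonded ring carbon were all six-membered aromatic rings, and 5-methylthiophen-2-yl now brings a five-membered aromatic ring with a sulfur atom to that place without leaving the scatter: a 1.2-fold higher number from compound 1 to compound 4 (0.08 log units; within the scatter), a 1.1-fold higher number from compound 2 to compound 4 (0.05 log units; within the scatter) and a 1.3-fold lower number from compound 3 to compound 4 (0.13 log units; within the scatter). Every pair among the four compounds now lies within the scatter, so neither ring size nor the swap to this hetero atom has separated any compound at this position. No measurement is at hand that would explain this flat picture.

The compounds shown leave open whether a cyclohexyl ring, a plain alkyl chain, or a phenyl ring carrying an amine or a carboxylic acid at this position would give a step beyond the scatter in this assay. Going by these compounds, all four also keep the rest of the shared core unchanged, so the effect of an exchange elsewhere on it remains open.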